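This account rests on a few compounds, and the source may have more. Where it says the series, first, only, none or still open, it means among the compounds named here.

In a functional assay on PC-3 cells (Homo sapiens) for antiproliferative activity, read by sulforhodamine B assay (a lower number here means a stronger inhibitor of growth, a higher number a weaker inhibitor of growth), compound 1 `O=C(/C=C/c1ccc(O)cc1)c1c(O)cccc1OCCC1CCCC1` gives 3480 nM. Compound 2 `CC(C)(C)CCOc1cccc(O)c1C(=O)/C=C/c1ccc(C(=O)O)cc1` gives 6500 nM and compound 3 `CC(C)(C)CCOc1cccc(O)c1C(=O)/C=C/c1ccc(S(N)(=O)=O)cc1` gives 3250 nM, so compound 1 stands second highest of the three numbers, and its gaps to both neighbours lie within the scatter. Compound 4 `CCC(CC)COc1cccc(O)c1C(=O)/C=C/c1ccc(O)cc1` differs from compound 1 by pentan-3-yl in place of cyclopentylmethyl on a saturated chain carbon bound to an oxygen on an aromatic ring. Going by the values given here, the only measured step, a 2.0-fold lower number from compound 2 to compound 3 (0.30 log units; within the scatter), changes a group on the other ring, not the chain altered here, so it says little about this change. Among the compounds with values here, no measured pair varies the chain on the oxygen, so no step beyond the scatter is expected from compound 1 to compound 4, and compound 4 is expected to give 3500 nM, with a range from 1500 nM to 8000 nM, an expected step of a 1.0-fold higher number from compound 1 to compound 4 (0.00 log units; within the scatter).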

Compound 4, concentration for 50% growth inhibition: 3390 nM
Estimate against measurement, compound 4: 1.0-fold (0.01 log units) above; low and high end bracket the measured number.
By their numbers in this assay, from the lowest: compounds 3, 4, 1 and 2 (each within the scatter of the next).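

Going by these compounds alone, this is the first measured pair that varies the chain on the oxygen. In this assay, pentan-3-yl in place of cyclopentylmethyl gives a 1.0-fold lower number from compound 1 to compound 4 (0.01 log units; within the scatter), so on this saturated chain carbon the five-membered carbon ring can give way to an open chain without a step beyond the scatter. No evidence on the cause of this result is available here. Going by these compounds, what remains open is how this position responds to groups of another kind, such as an amine or a carboxylic acid on the chain, or to a much longer chain.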